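Aryl ether swap in a biaryl benzoic acid urea series

The compounds below may be only part of what the source reports. "The series", "measured", "known", "first", "only" and "open" are said of these compounds alone.

Measured compounds:
compound 1 `CC(C)(C)c1ccccc1Oc1ccc(-c2cccc(C(=O)O)c2)cc1NC(=O)Nc1ccccc1` — 1500 nM
compound 2 `COc1ccc(-c2ccc(Oc3ccccc3Cl)c(NC(=O)Nc3ccc(C)cc3)c2)cc1C(=O)O` — 830 nM

Both compounds were read in an assay on HeLa cells for inhibition of Indoleamine 2,3-dioxygenase 1 (Homo sapiens), with a stated time of 20 h; a lower number here means a stronger inhibitor, a higher number a weaker inhibitor. Compound 2 gives 830 nM and compound 1 gives 1500 nM; the gap between the two lies within the usual scatter of this assay, so the two cannot be set apart on the numbers alone. Compound 3 `COc1ccc(-c2ccc(Oc3cccc4c3CCC4)c(NC(=O)Nc3ccc(C)cc3)c2)cc1C(=O)O` carries a change on the aryl ether of compound 2: 2,3-dihydro-1H-inden-4-yl in place of 2-chlorophenyl on an oxygen on an aromatic ring, in other words 2,3-dihydro-1H-inden-4-yl in place of 2-chlorophenyl on an oxygen on an aromatic ring. For the measured compounds named here, no measured pair in the set shows this change, so the size of the step is open. The expected step of a 1.2-fold lower number from compound 2 to compound 3 (0.07 log units; within the scatter) is small, with no clear direction beyond the scatter, since the two aryl groups carry no donors or acceptors and differ only in the ring system. Compound 3 is expected at 700 nM, within a range of 250 nM to 2000 nM.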

Compound 3, half-maximal inhibitory concentration: 280 nM
Beside the measured number, compound 3's estimate is 2.5-fold (0.40 log units) above it; low and high end bracket the measured number.
By their numbers in this assay, from the lowest: compound 3; then compounds 2 and 1 (each within the scatter of the next).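

The group on this oxygen matters in this assay: 2,3-dihydro-1H-inden-4-yl in place of 2-chlorophenyl gives a 3.0-fold lower number from compound 2 to compound 3 (0.47 log units; beyond the scatter) and so moves the number beyond the scatter. Compounds 1 and 2 differ in more than one place, so they could not show this for the aryl ether alone. The step loses the chlorine and gains the five-membered non-aromatic ring at once, and no measurement on these compounds explains it.

Going by these compounds, the effect of 2-methylphenyl or 1-naphthyl on the same oxygen remains open, and either would help separate the loss of the chlorine from the gain of the ring. Also open, on these data alone, is whether the step carries over to the core of compound 1, where the aryl ether is a different group again.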